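The compounds below may be only part of what the source reports. "The series", "measured", "known", "first", "only" and "open" are said of these compounds alone.

Measured so far:
- compound 1 `COC(=O)C(c1ccccc1)n1nnnc1[C@@H](COCc1ccccc1)NC(=O)C(C)(C)N` — 470 nM
- compound 2 `CC(C)(N)C(=O)N[C@H](COCc1ccccc1)c1nnn(Cc2ccccc2NS(C)(=O)=O)n1` — > 5000 nM
- compound 3 `CC(C)(N)C(=O)N[C@H](COCc1ccccc1)c1nnn(C/C=C/c2ccccc2)n1` — > 5000 nM

All three were tested in an assay on isolated protein for displacement of a labelled ligand from growth hormone secretagogue receptor type 1 (Homo sapiens), with a stated time of 1 h; a higher number here means a weaker inhibitor, a lower number a stronger inhibitor. Compound 1 gives a readable number, 470 nM. Compound 2 returns only a limit of the assay, > 5000 nM. Compound 3 likewise returns only a limit, > 5000 nM, so it stands at the weak end of the numbers shown, with no exact value. Going by the values given here, the single one-place step measured so far, a step that the two limits leave unreadable from compound 2 to compound 3, cannot be sized because of the limit of > 5000 nM in this assay, at which 2 of the 3 values shown sit.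

Compound 4 `CC(C)(N)C(=O)N[C@H](COCc1ccccc1)c1nnn(CCCCC#N)n1` is the next compound and has not yet been measured. It differs from compound 3 by 3-cyanopropyl in place of 2-phenylethenyl on a saturated chain carbon bound to an aromatic nitrogen. Among the compounds with values here, no measured step covers this kind of change, and the only comparable step, the one from compound 2 to compound 3, was itself unreadable. With compound 3 already at the limit, there is no basis for expecting a move in either direction beyond the scatter. Compound 4 is therefore estimated at 6000 nM, within 2000 nM to 20000 nM, and most likely reported again only as a limit. The expected step is a step that the limit leaves unreadable from compound 3 to compound 4, meaning no readable change.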

Compound 4, inhibition constant: > 5000 nM
Compound 4 was reported as a limit; the forecaster's own chance of this, stated with the estimate: 70%; the middle value lies beyond the limit too.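

Compound 4 is reported only as a limit, so neither its step from compound 2 nor its step from compound 3 can be read, because each pair sits at the same limit: the limit of > 5000 nM in this assay, at which 3 of the 4 values shown sit.

From the compounds shown here alone, how strong an inhibitor compound 2, compound 3 and compound 4 each really is, and whether their different groups change that at all, stays open.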